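A few compounds are considered here, and "the series" means these few. Any claim that something is new, unique, unknown or untested is made for them only; others in the source may bear on it.

Compound 1 `C=C1[C@@H](O)[C@H](n2cnc3c(O)nc(N)nc32)O[C@@H]1CO` and compound 2 `C=C1[C@@H](O)[C@H](n2cnc3c(O)ncnc32)O[C@@H]1CO` share one core. In a functional assay on MT4 cells (Homo sapiens) for inhibition (on this read-out higher numbers stand for weaker inhibition and lower numbers for stronger inhibition), compound 1 gives only a limit of the assay, > 200000 nM. In this assay compound 2 also gives only a limit, > 200000 nM. The change between them is hydrogen in place of amino on an aromatic carbon; the step that the two limits leave unreadable from compound 1 to compound 2 is not readable because both values sit at the limit of > 200000 nM in this assay, at which 2 of the 3 values shown sit. Compound 3 `C=C1[C@H](n2cnc3c(N)nc(N)nc32)O[C@H](CO)[C@H]1O` gives only a limit in this assay, > 500000 nM. The difference between the core of compound 3 and the core of compound 1 is not broken down here. Compound 4 `C=C1[C@H](n2cnc3c(N)ncnc32)O[C@H](CO)[C@H]1O` is not yet measured; it differs from compound 3 by hydrogen in place of amino on an aromatic carbon, the same kind of change as from compound 1 to compound 2, the place here being meta to an amino group rather than meta to a hydroxy group. Compound 3 sits at the limit of > 500000 nM in this assay, at which 1 of the 3 values shown sits, and on this the expectation rests. Compound 4 is expected to give about 500000 nM in this assay, an expected step of a number no higher from compound 3 to compound 4 (the limit leaves the size open), most likely again only a limit.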

Compound 4, half-maximal inhibitory concentration: 131000 nM
The estimate for compound 4 lay 3.8-fold (0.58 log units) above the measured number; low and high end bracket the measured number.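

In this assay, hydrogen in place of amino on an aromatic carbon gives an at least 3.8-fold lower number from compound 3 to compound 4 (0.58 log units; beyond the scatter), so on the core of compound 3 the change lowers the number beyond the scatter, by a size that stays open because one end of the step is a limit: the limit of > 500000 nM in this assay, at which 1 of the 4 values shown sits.

The same change on the core of compound 1 cannot be read because compound 1 and compound 2 both stand at a limit: the limit of > 200000 nM in this assay, at which 2 of the 4 values shown sit.

The series therefore shows the change acting on one core only, and it neither confirms nor refutes that the result carries over to the other.

Open, from the compounds shown here alone, is how a methyl group or a chlorine on that aromatic carbon, between two ring nitrogen atoms, would compare with the hydrogen of compound 4. Also open, going by these compounds, is whether any such replacement would give a readable number on the core of compound 1.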